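The compounds below may be only part of what the source reports. "The series", "measured", "known", "first", "only" and "open" are said of these compounds alone.

In an in vivo ADME assay on the whole organism for pharmacokinetics, with Rattus norvegicus as the target, at a dose of 0.5 mg/kg by the intravenous route (on this read-out higher numbers stand for fast clearance and lower numbers for slow clearance), compound 1 `CC(=O)Nc1cc(-c2c(Nc3ccn(C)n3)nc3cccnn23)nc(C)n1` gives 18.3 mL/min/kg. Compound 2 `Cc1nc(Nc2cccnc2)cc(-c2c(Nc3cc[nH]n3)nc3cccnn23)n1` was also entered in this assay but returned "not determined" (no result reported), so compound 2 stands on no number in this read-out. Compound 3 `Cc1nccc(-c2c(Nc3cc[nH]n3)nc3cccnn23)n1` differs from compound 2 in one place: hydrogen in place of (pyridin-3-yl)amino on an aromatic carbon. For the measured compounds named here, no measured step exists for this change, and compound 2 itself carries no value, so the size and direction of the step cannot be read from the data; a step within the usual scatter or beyond it remains open. The only anchor in this assay is compound 1 at 18.3 mL/min/kg. Compound 3 is estimated at 20 mL/min/kg, expected to fall between 8 mL/min/kg and 50 mL/min/kg.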

Compound 3, clearance: 31.7 mL/min/kg
Beside the measured number, compound 3's estimate is 1.6-fold (0.20 log units) below it, and the stated range covers the measured number.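

No step can be read between compound 2 and compound 3: compound 2 stands on no number in this assay and compound 3 gives 31.7 mL/min/kg there. These compounds leave open whether replacing (pyridin-3-yl)amino with hydrogen shifts clearance at all. No evidence bears on this result.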